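The source may hold more compounds than are shown below. What is called first, only, known or untested is meant among the compounds shown, and "the series" means these compounds.

- compound 1 `CCCCCCNC(=O)c1cc(C#Cc2cc(OC)ccc2OC)ccc1OC` gives 7900 nM
- compound 2 `CCCCCCNC(=O)c1cc(/C=C\c2cc(O)ccc2O)ccc1O` gives 1200 nM

In a functional assay on CCRF-CEM cells (Homo sapiens) for antiproliferative activity (a lower number here means a stronger inhibitor of growth, a higher number a weaker inhibitor of growth), compound 1 stands highest of the two measured compounds at 7900 nM and its gap to compound 2 at 1200 nM lies beyond the scatter. Both carry the hexylcarbamoyl group, so this pair shows nothing about removing it.

Compound 3 `COc1ccc(OC)c(C#Cc2ccc(OC)c(C(=O)O)c2)c1` has not yet been measured. Its difference from compound 1 is hydroxy in place of hexylamino on a carbonyl carbon and amounts to hydroxy in place of hexylamino on a carbonyl carbon, or hexylcarbamoyl to carboxy. For the measured compounds named here, no measured pair isolates this change, so the expectation is a judgement with wide uncertainty. A shift beyond the scatter toward weaker growth inhibition seems likely, and the expected step is a 4.4-fold higher number from compound 1 to compound 3 (0.65 log units; beyond the scatter) in this direction. For compound 3 the estimated value is 35000 nM with an expected range of 10000 nM to 120000 nM in this assay.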

Compound 3, concentration for 50% growth inhibition: 55000 nM
Compound 3: the middle estimate sits 1.6-fold (0.20 log units) below what was measured, and the stated range covers the measured number.
By their numbers in this assay, from the lowest: compound 2; then compound 1; then compound 3.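

Replacing hexylamino with hydroxy on the carbonyl carbon, which turns hexylcarbamoyl into carboxy, gives a 7.0-fold higher number from compound 1 to compound 3 (0.84 log units; beyond the scatter) in this assay. This is the only pair shown that differs in one place, so it gives the first direct reading of this position: on this core, the hexylcarbamoyl compound inhibits growth more strongly than the carboxy compound. No measurement at hand explains the size or direction of this step.

From the compounds shown here alone, it remains open whether the hexyl chain itself matters, since a shorter butyl chain, an unsubstituted amide or a methyl ester on the same carbonyl carbon would each separate the chain from the amide. Going by these compounds, compound 2 differs from compound 1 in more than one place, so whether the same change would have a similar effect on the core of compound 2 also remains open.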